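The compounds below may be only part of what the source reports. "The series", "measured", "known", "first", "only" and "open" are said of these compounds alone.

Compound 3, whose structure is `CCC[C@@H]1O[C@@]2(CC1=O)CN1CCC2C1`, is tested in a functional assay on the whole organism (Hippocampus) for activation, with Rattus norvegicus as the target; a higher number here means a larger maximal response, a lower number a smaller maximal response. In this assay, going by the values given here, compound 3 gives 0%, which is the lowest of the three numbers so far. Its nearest neighbour is compound 2, `CC[C@H]1O[C@@]2(CC1=O)CN1CCC2C1`, which gives 39% in this assay. Furthest away is compound 1, `CC[C@@H]1O[C@@]2(CC1=O)CN1CCC2C1`, which in this assay gives 47%. The step from compound 1 to compound 3 is a number 47 percentage points lower from compound 1 to compound 3 (beyond the scatter), a change of methyl in place of hydrogen on a saturated chain carbon, two bonds along the chain from a saturated ring carbon.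

Compound 4, `CCC[C@H]1O[C@@]2(CC1=O)CN1CCC2C1`, has not yet been measured. It differs from compound 3 only in this way: the two compounds have the same atoms and bonds; at least one stereo element is drawn with a configuration in one of them and without one in the other: 1 of 4 stereo elements differ; a stereocentre at a saturated ring carbon is drawn S in compound 3 and R in compound 4. Among the compounds with values here, the same kind of change, an inversion at a saturated ring carbon, occurs between compound 1 and compound 2, where the step was a number 8 percentage points lower from compound 1 to compound 2 (within the scatter); the one piece of evidence on that step is the fact that one of compounds 1 and 2 is drawn with a defined configuration and the other without, at the place where they differ. Because that stereochemical step a number 8 percentage points lower from compound 1 to compound 2 (within the scatter) stayed inside the scatter, the corresponding step for compound 4 is expected to be small as well. Compound 4 is therefore estimated to give 5% in this assay, within the range 0% to 20%, a step of a number 5 percentage points higher from compound 3 to compound 4 (within the scatter) that is expected to lie within the usual scatter.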

Compound 4, intrinsic activity: the largest response reached, in percent of the reference agonist's: 0%
The estimate for compound 4 lay 5 percentage points above the measured number; the range from low to high includes it.
By their numbers in this assay, from the lowest: compounds 3 and 4 (each within the scatter of the next); then compounds 2 and 1 (each within the scatter of the next).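

The inversion at the saturated ring carbon now has a second reading in this assay: no change at the digits printed from compound 3 to compound 4 (within the scatter), which matches a number 8 percentage points lower from compound 1 to compound 2 (within the scatter) in staying inside the scatter, so neither pair shows a measurable effect of this stereocentre on the maximal response. The chain change, methyl in place of hydrogen on a saturated chain carbon, two bonds along the chain from a saturated ring carbon, now also has a second reading, a number 39 percentage points lower from compound 2 to compound 4 (beyond the scatter), so the large drop is no longer a single observation and appears with either configuration at the ring carbon: the same change on two cores in this assay, a number 47 percentage points lower (beyond the scatter) from compound 1 to compound 3 and a number 39 percentage points lower (beyond the scatter) from compound 2 to compound 4, 8 percentage points apart, within the scatter of two such steps. The reading of the inversion in this pair carries one reservation, which also applies to the earlier pair: the fact that one of compounds 3 and 4 is drawn with a defined configuration and the other without, at the place where they differ.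

The compounds shown leave open how the maximal response changes along the chain, for example with a methyl group or a longer butyl chain at this ring carbon. They also leave open whether a branched isopropyl group, or a hydroxyl in place of the carbonyl, would give a response in this assay.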